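The source may report more compounds than this note shows. Statements on the series, on what has been measured and on what is new or still open speak of the compounds shown alone.

Of the compounds shown here, three from this series have been measured in a functional assay on HSC-2 cells (Homo sapiens) for cytotoxicity, read by MTT assay, with a stated time of 48 h; a higher number here means that more compound is tolerated, a lower number that less compound is tolerated. Compound 1 `O=C1/C(=C/c2ccccc2)CN(C(=O)CCSCCS(=O)(=O)O)C/C1=C\c1ccccc1` gives 154000 nM. Compound 2 `O=C1/C(=C/c2ccccc2)CN(C(=O)CCSCCO)C/C1=C\c1ccccc1` gives 1530 nM, and compound 3 `O=C1/C(=C/c2ccc(Cl)cc2)CN(C(=O)CCSCCO)C/C1=C\c1ccc(Cl)cc1` gives 660 nM, the lowest number of the three, with its steps to both others beyond the scatter. The difference between the cores of compound 2 and compound 3 is not broken down here. Compound 1 and compound 2 share a core and differ only by sulfo in place of hydroxy on a saturated chain carbon, two bonds along the chain from a sulfur, a change that produced a 100-fold higher number from compound 2 to compound 1 (2.00 log units; beyond the scatter).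

Compound 4 `O=C1/C(=C/c2ccc(Cl)cc2)CN(C(=O)CCSCCS(=O)(=O)O)C/C1=C\c1ccc(Cl)cc1` has not yet been measured. It differs from compound 3 by sulfo in place of hydroxy on a saturated chain carbon, two bonds along the chain from a sulfur, which is the same change as that from compound 2 to compound 1, at the same place. Going by the values given here, the expected step is a 100-fold higher number from compound 3 to compound 4 (2.00 log units; beyond the scatter), set beside the earlier one because the identical change gave a 100-fold higher number from compound 2 to compound 1 (2.00 log units; beyond the scatter) and there is nothing among the measured compounds to suggest it would act otherwise on the core of compound 3. For compound 4 the estimated value in this assay is therefore 66000 nM, with a plausible range from 15000 nM to 250000 nM.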

Compound 4, half-maximal cytotoxic concentration: 29700 nM
Compound 4: middle estimate off by 2.2-fold (0.35 log units), on the high side; the range from low to high includes it.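

In this assay, sulfo in place of hydroxy on a saturated chain carbon, two bonds along the chain from a sulfur, gave a 45-fold higher number from compound 3 to compound 4 (1.65 log units; beyond the scatter) on the core of compound 3, the same direction as on the core of compound 2. Set side by side, the two steps do not differ beyond what repeated measurements would be expected to scatter: the same change on two cores in this assay, a 100-fold higher number (2.00 log units; beyond the scatter) from compound 2 to compound 1 and a 45-fold higher number (1.65 log units; beyond the scatter) from compound 3 to compound 4, 2.2-fold (0.35 log units) apart, within the scatter of two such steps. Going by these compounds alone, this shows that the change carried over between these two cores, in direction and, within the scatter, in size, but it rests on only two pairs and does not show that the same would hold on any other core, nor why the number moves.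

The compounds shown leave open whether a carboxylic acid or a phosphonic acid at the same place, or a longer chain carrying the sulfo group, would give a step of similar size. They also leave open how the change would behave on a core carrying methoxy or nitro in place of the chlorine.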